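The compounds below may be only part of what the source reports. "The series", "measured", "known", "first", "only" and "open" are said of these compounds alone.

Measured in a functional assay on K562 cells (Homo sapiens) for antiproliferative activity, read by sulforhodamine B assay, with a stated time of 48 h; on this read-out higher numbers stand for weaker inhibition and lower numbers for stronger inhibition:
- compound 1 `O=C1NCCN1c1ccc(S(=O)(=O)Nc2cccc(Br)c2)cc1`: 87 nM
- compound 2 `Cc1ccc(C)c(NS(=O)(=O)c2ccc(N3CCNC3=O)cc2)c1`: 72 nM
- compound 3 `O=C1NCCN1c1ccc(S(=O)(=O)Nc2cccc(Cl)c2)cc1`: 69 nM

Compound 3 cannot be separated from the other two: a 1.0-fold lower number from compound 2 to compound 3 (0.02 log units; within the scatter) and a 1.3-fold lower number from compound 1 to compound 3 (0.10 log units; within the scatter) are both within the scatter. Compound 4 `COc1cccc(NS(=O)(=O)c2ccc(N3CCNC3=O)cc2)c1` carries methoxy in place of chloro on an aromatic carbon, meta to a large group (methoxy in place of chloro on an aromatic carbon). For the measured compounds named here, no measured compound carries methoxy, so no direct precedent exists. The nearest evidence is a 1.3-fold lower number from compound 1 to compound 3 (0.10 log units; within the scatter), a swap of one group at that carbon, and a 1.2-fold lower number from compound 1 to compound 2 (0.08 log units; within the scatter), a swap of the whole aryl group; neither leaves the scatter. No step beyond the scatter is therefore expected in this assay, and no direction can be favoured. The estimated step is a 1.1-fold higher number from compound 3 to compound 4 (0.04 log units; within the scatter). For compound 4 the estimated value is 75 nM, with an expected range of 30 nM to 190 nM.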

Compound 4, half-maximal inhibitory concentration: 230 nM
For compound 4 the middle estimate is 3.1-fold (0.49 log units) below the measured one; measured number above the stated range.
By their numbers in this assay, from the lowest: compounds 3, 2 and 1 (each within the scatter of the next); then compound 4.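

In this assay the aromatic carbon first shows a step beyond the scatter with methoxy, which gives a 3.3-fold higher number from compound 3 to compound 4 (0.52 log units; beyond the scatter) and, against bromo, a 2.6-fold higher number from compound 1 to compound 4 (0.42 log units; beyond the scatter) while the swap between the two halogens stays at a 1.3-fold lower number from compound 1 to compound 3 (0.10 log units; within the scatter) and so does not separate them. The 3-methoxyphenyl group also stands apart from 2,5-dimethylphenyl on the sulfonamide nitrogen, with a 3.2-fold higher number from compound 2 to compound 4 (0.50 log units; beyond the scatter) as the step. From the compounds shown here alone, whether a hydroxyl, an amine or an ethoxy group at this carbon would read with the halogens or with methoxy stays open. Nothing shown here accounts for the change with methoxy.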